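Working notes: fluoro for hydrogen on the ring of compound 1

The compounds below may be only part of what the source reports. "The series", "measured", "known", "first", "only" and "open" are said of these compounds alone.

Measured compounds:
compound 1, `N/C(=N\NC(=S)N1CCCCCC1)c1ccccn1`, 76.5%
compound 2, `Cc1ccnc(/C(N)=N/NC(=S)N2CCCCCC2)c1`, 75.9%

Both were tested in a functional assay on MCF7 cells (Homo sapiens) for cytotoxicity, read by MTT assay, with a stated time of 72 h, tested at 30 uM; a higher number here means more inhibition of growth at the concentration tested, a lower number less inhibition of growth. Compound 1 gives 76.5% and compound 2 gives 75.9%, and the change a number 0.6 percentage points lower from compound 1 to compound 2 (within the scatter) lies within the scatter, so the two stand together and no order between them can be read.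

Compound 3, `N/C(=N\NC(=S)N1CCCCCC1)c1ccc(F)cn1`, is not yet measured. It differs from compound 1 by fluoro in place of hydrogen on an aromatic carbon. Among the measured compounds shown here, the only measured step on the same core, a number 0.6 percentage points lower from compound 1 to compound 2 (within the scatter), swaps a small group onto an aromatic carbon of that ring and moves the number by almost nothing. On that basis no step beyond the scatter is expected for compound 3 in this assay, and the estimated change a number 2.5 percentage points lower from compound 1 to compound 3 (within the scatter) is small. Compound 3 is therefore estimated at 74%, with a range from 60% to 85%.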

Compound 3, percent growth inhibition at one concentration: 68.2%
Compound 3: middle estimate off by 5.8 percentage points, on the high side; the range from low to high includes it.
By their numbers in this assay, from the lowest: compounds 3, 2 and 1 (each within the scatter of the next).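

In this assay, among the compounds shown here, fluoro in place of hydrogen on an aromatic carbon, two atoms from the ring nitrogen and para to a large group, gives a number 8.3 percentage points lower from compound 1 to compound 3 (within the scatter), so this exchange produces no step that can be read. The position therefore carries a fluorine, a heavy atom with no hydrogen-bond donors or acceptors counted for it, without leaving the scatter, and the methyl exchange in the other ring-substituted compound likewise gives a number 0.6 percentage points lower from compound 1 to compound 2 (within the scatter). No additional measurement bears on the result for fluoro here.

The compounds shown leave open whether an amine or a carboxylic acid at this position would give a step beyond the scatter. They also leave open whether a longer chain, such as a butyl group, would do so at the same place.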